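Hydroxy for nitro on the hydrazone aryl: compound 4

The source may report more compounds than this note shows. Statements on the series, on what has been measured and on what is new or still open speak of the compounds shown alone.

Measured so far in a functional assay on BGC-823 cells (Homo sapiens) for cytotoxicity, read by MTT assay, with a stated time of 48 h; on this read-out lower numbers stand for stronger inhibition and higher numbers for weaker inhibition:
compound 1, `O=C(CSc1nnc(-c2ccncc2)o1)N/N=C/c1ccc([N+](=O)[O-])cc1`: 31500 nM
compound 2, `O=C(CSc1nnc(-c2ccncc2)o1)N/N=C/c1ccc(O)cc1`: 7940 nM
compound 3, `O=C(CSc1nnc(-c2ccncc2)o1)N/N=C/c1ccccc1[N+](=O)[O-]`: 41600 nM

Three analogues share one core and differ only in the aryl group on the hydrazone carbon. Compound 3 gives the highest number of the three in this assay: a 1.3-fold higher number from compound 1 to compound 3 (0.12 log units; within the scatter) keeps it level with compound 1, while a 5.2-fold higher number from compound 2 to compound 3 (0.72 log units; beyond the scatter) sets it clearly apart from compound 2.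

Compound 4, `O=C(CSc1nnc(-c2ccncc2)o1)N/N=C/c1ccccc1O`, is not yet measured. It differs from compound 3 by hydroxy in place of nitro on an aromatic carbon. Going by the values given here, the only measured precedent for this exchange is on the 4-substituted ring, a 4.0-fold lower number from compound 1 to compound 2 (0.60 log units; beyond the scatter), a modest step beyond the scatter. Moving the nitro from the 4-position to the 2-position left the number unchanged (a 1.3-fold higher number from compound 1 to compound 3 (0.12 log units; within the scatter)), so the hydroxy-for-nitro exchange is expected to carry over: a modest lower number for compound 4, a 4.0-fold lower number from compound 3 to compound 4 (0.60 log units; beyond the scatter). Compound 4 is therefore estimated at 10500 nM, within 4000 nM to 26000 nM.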

Compound 4, half-maximal inhibitory concentration: 6160 nM
Beside the measured number, compound 4's estimate is 1.7-fold (0.23 log units) above it; measured number inside the range.
By their numbers in this assay, from the lowest: compounds 4 and 2 (each within the scatter of the next); then compounds 1 and 3 (each within the scatter of the next).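

In this assay, hydroxy in place of nitro now has a second reading, a 6.8-fold lower number from compound 3 to compound 4 (0.83 log units; beyond the scatter), on the 2-nitrophenyl to 2-hydroxyphenyl pair, and the exchange repeats across the two ring placements: the same change on two cores in this assay, a 4.0-fold lower number (0.60 log units; beyond the scatter) from compound 1 to compound 2 and a 6.8-fold lower number (0.83 log units; beyond the scatter) from compound 3 to compound 4, 1.7-fold (0.23 log units) apart, within the scatter of two such steps. The place of the hydroxy gives no readable difference, a 1.3-fold lower number from compound 2 to compound 4 (0.11 log units; within the scatter), just as the place of the nitro gave none, a 1.3-fold higher number from compound 1 to compound 3 (0.12 log units; within the scatter). Across these four compounds the identity of the group, not its place on the ring, separates the numbers, and the step with both changed at once, a 5.1-fold lower number from compound 1 to compound 4 (0.71 log units; beyond the scatter), is of the same modest size.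

As far as these compounds go, whether an amine or a methoxy group at these same places would read like hydroxy or like nitro stays open. Also open, from the compounds shown here alone, is whether the exchange holds when the shared core is changed elsewhere.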